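From 4-chlorophenyl to 3-chlorophenyl

A few compounds are considered here, and "the series" means these few. Any claim that something is new, unique, unknown or untested is made for them only; others in the source may bear on it.

In an ADME assay on HepG2 cells (Homo sapiens) for cytotoxicity, with a stated time of 72 h (on this read-out higher numbers stand for an effect only at larger amounts of compound and lower numbers for an effect already at smaller amounts), compound 1 `Cc1cc(NC(=O)Nc2cccnc2)c2ccccc2n1` gives > 25000 nM, which is a limit and not a number. Compound 2 `Cc1cc(NC(=O)Nc2ccc(Cl)cc2)c2ccccc2n1` gives > 25000 nM, which is also a limit, so it has no exact number. Compound 3 `Cc1cc(NC(=O)Nc2cccc(Cl)c2)c2ccccc2n1` differs from it by 3-chlorophenyl in place of 4-chlorophenyl on an amide-type nitrogen, with 3-chlorophenyl in place of 4-chlorophenyl. For the measured compounds named here, the only measured step is a step that the two limits leave unreadable from compound 1 to compound 2, and the evidence is the limit of > 25000 nM in this assay, at which 2 of the 2 values shown sit. On that basis, the expected step is a step that the limit leaves unreadable from compound 2 to compound 3, with no larger change beyond the scatter expected in either direction. The estimate for compound 3 is 30000 nM, with an expected range of 15000 nM to 60000 nM.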

Compound 3, half-maximal effective concentration: 19000 nM
Beside the measured number, compound 3's estimate is 1.6-fold (0.20 log units) above it, and the stated range covers the measured number.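

With 3-chlorophenyl on the amide-type nitrogen, this assay gives its first exact number in this series, and so a first sign of cytotoxicity that can be placed on a scale. Swapping 4-chlorophenyl for 3-chlorophenyl shows an at least 1.3-fold lower number from compound 2 to compound 3 (0.11 log units; that floor lies within the scatter), while swapping pyridin-3-yl for 3-chlorophenyl shows an at least 1.3-fold lower number from compound 1 to compound 3 (0.11 log units; that floor lies within the scatter). The true size of both steps stays unknown because each starts from a limit: the limit of > 25000 nM in this assay, at which 2 of the 3 values shown sit.

On these data alone, whether either step really exceeds the scatter remains open. So does what an amine or a carboxylic acid would give in that place on the nitrogen.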